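Swapping an Ester for a Cyclic Amide on a Chalcone

A few compounds are considered here, and "the series" means these few. Any claim that something is new, unique, unknown or untested is made for them only; others in the source may bear on it.

Three compounds share one core. Compound 1 `CCCOC(=O)c1ccc(/C=C/C(=O)c2cc(OC)ccc2OC)cc1` gives 6010 nM in a functional assay on NTUB1 cells (Homo sapiens) for cytotoxicity, read by MTT assay, with a stated time of 72 h; on this read-out higher numbers stand for weaker inhibition and lower numbers for stronger inhibition. Compound 2 `COc1ccc(OC)c(C(=O)/C=C/c2ccc(C(=O)OC(C)C)cc2)c1` gives 4420 nM in this assay; its number sits close to that of compound 1, since a 1.4-fold lower number from compound 1 to compound 2 (0.13 log units; within the scatter), and above that of compound 3. Compound 3 `COc1ccc(OC)c(C(=O)/C=C/c2ccc(C(=O)NC(C)C)cc2)c1` gives 1970 nM, and both a 2.2-fold lower number from compound 2 to compound 3 (0.35 log units; beyond the scatter) and a 3.1-fold lower number from compound 1 to compound 3 (0.48 log units; beyond the scatter) are modest steps beyond the scatter. Compound 4 `COc1ccc(OC)c(C(=O)/C=C/c2ccc(C(=O)N3CCCC3)cc2)c1` is not yet measured; it differs from compound 2 by pyrrolidin-1-yl in place of isopropoxy on a carbonyl carbon. Going by the values given here, the two ester-to-amide steps bear on this change, while no measured step tells how a ring on the amide compares with isopropylamino. A modest lowering is therefore expected, about a 1.8-fold lower number from compound 2 to compound 4 (0.25 log units; within the scatter). Compound 4 is expected to give 2500 nM, between 1000 nM and 6000 nM.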

Compound 4, half-maximal inhibitory concentration: 1260 nM
Compound 4: the middle estimate sits 2.0-fold (0.30 log units) above what was measured; measured number inside the range.
By their numbers in this assay, from the lowest: compounds 4 and 3 (each within the scatter of the next); then compounds 2 and 1 (each within the scatter of the next).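

In this assay, the lower number seen on replacing an ester with an amide also holds when the amide carries a ring: pyrrolidin-1-yl on the carbonyl carbon gives a 3.5-fold lower number from compound 2 to compound 4 (0.55 log units; beyond the scatter) and a 4.8-fold lower number from compound 1 to compound 4 (0.68 log units; beyond the scatter), both modest steps. Against the open-chain amide, the ring gives a 1.6-fold lower number from compound 3 to compound 4 (0.19 log units; within the scatter), so removing the amide hydrogen and closing the ring brings no clear difference. Nothing measured here explains these numbers.

Still open, on these data alone, is whether a larger ring, such as piperidine or morpholine, would behave like pyrrolidin-1-yl. A carboxylic acid on this carbonyl carbon also remains untested among the compounds shown.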